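The source may hold more compounds than are shown below. What is called first, only, known or untested is meant among the compounds shown, and "the series" means these compounds.

Measured so far:

Compound 1 `COc1ccc(/C=C2\S/C(=N\c3ccccc3)N(C)C2=O)cc1`: in an ADME assay on TERT-RPE1 cells (Homo sapiens) for cytotoxicity, read by MTT assay, with a stated time of 72 h (on this read-out lower numbers stand for stronger inhibition and higher numbers for weaker inhibition), compound 1 gives > 100000 nM, which is a limit of the assay rather than a number.

Compound 2 `COc1ccc(/C=C2/CN(C)/C(=N/c3ccc(OC)cc3)S2)cc1`: in this assay compound 2 gives 65900 nM.

Compound 3 `FC(F)(F)c1cc(/N=C2/NC/C(=C/c3ccccc3)S2)cc(C(F)(F)F)c1`: in this assay compound 3 gives 32800 nM.

Among the three compounds, compound 1 stands at the top of the numbers shown, that is, at the limit of > 100000 nM in this assay, at which 1 of the 3 values shown sits. Compounds 2 and 3 each give an actual number, both pointing to weak inhibition of cell growth.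

Compound 4 `COc1ccc(/C=C2\S/C(=N\c3ccc(F)cc3)N(C)C2=O)cc1` has not yet been measured. It differs from compound 1 in one place: fluoro in place of hydrogen on an aromatic carbon. Among the compounds with values here, no pair of measured compounds differs in a single place, so no measured step shows what such a change does in this assay. The step expected from compound 1 to compound 4 is a number no higher from compound 1 to compound 4 (the limit leaves the size open), in either direction nothing beyond the usual scatter. Compound 4 is therefore estimated at about 100000 nM, with a range from 40000 nM to 250000 nM, and it is expected that the assay may again report only a limit.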

Compound 4, half-maximal inhibitory concentration: > 100000 nM
Compound 4 was reported as a limit (the forecaster's own chance of this, stated with the estimate: 70%); the middle value sits exactly at the limit.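

In this assay compound 1 and compound 4 are each reported only as a limit, so no step can be read between them: the limit of > 100000 nM in this assay, at which 2 of the 4 values shown sit. The compounds shown leave open whether fluoro in place of hydrogen on an aromatic carbon shifts this read-out at all, and in which direction.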